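A Carboxy Group in Place of Trifluoromethoxy

The compounds below may be only part of what the source reports. "The series", "measured", "known", "first", "only" and "open" are said of these compounds alone.

Two compounds share a core and differ in the group hung from it. Compound 1 `Cc1n[nH]c(C(=O)O)c1Cc1ccccc1-c1ccc(F)cc1` and compound 2 `Cc1n[nH]c(C(=O)O)c1Cc1cccc(-c2ccc(OC(F)(F)F)cc2)c1` were both tested in an assay on isolated protein for inhibition of 2-Hydroxyacid oxidase 2 (Homo sapiens), tested at 10 uM; on this read-out lower numbers stand for a weaker effect and higher numbers for a stronger effect at the one concentration tested. In this assay compound 1 gives 56%. In this assay compound 2 gives 34%, the lowest of the two numbers in hand; compound 1 stands higher by a margin beyond the usual scatter. Since the two structures differ in more than one place, nothing beyond their two values can be said of that gap.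

Compound 3 `Cc1n[nH]c(C(=O)O)c1Cc1cccc(-c2ccc(C(=O)O)cc2)c1` has not yet been measured. It differs from compound 2 in a single place: carboxy in place of trifluoromethoxy on an aromatic carbon. Within the data shown here, no pair of measured compounds shows this same change, so there is no measured step to gauge its size against. In this assay the expected step is a number 1 percentage points higher from compound 2 to compound 3 (within the scatter), which the author takes to lie within the scatter and in no clear direction. Compound 3 is accordingly estimated to give 35% in this assay, with a range from 10% to 60%.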

Compound 3, a percentage reported as inhibition, at one concentration (the size of the read-out at that concentration, not a potency): 15%
For compound 3 the middle estimate is 20 percentage points above the measured one; the range from low to high includes it.
By their numbers in this assay, from the lowest: compound 3; then compound 2; then compound 1.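

In this assay, carboxy in place of trifluoromethoxy on an aromatic carbon, para to a large group, gives a number 19 percentage points lower from compound 2 to compound 3 (beyond the scatter). Among these compounds, this is the first change in the set made at one place alone, and it shows that the read-out at the single concentration tested is sensitive to what sits on this carbon of the six-membered aromatic ring: the exchange of these two groups, with the rest of the structure held fixed, moves the number beyond the usual scatter. Nothing in the data at hand accounts for the size or direction of this step, so the counted differences between the two groups, in heavy atoms and hydrogen-bond donors, remain a description only.

The compounds shown leave open whether the lower number goes with the arrival of carboxy or the departure of trifluoromethoxy, a question on which an amine, a methyl ester or a primary amide at this same carbon would bear. Compound 1 differs from compound 3 in more than one place, so it cannot say whether this step would hold with the other arrangement of the two aromatic rings.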